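The compounds below may be only part of what the source reports. "The series", "measured", "known", "first", "only" and "open" are said of these compounds alone.

In an ADME assay on WI-38 cells (Homo sapiens) for cytotoxicity, read by MTT assay, with a stated time of 72 h (on this read-out lower numbers stand for stronger inhibition and higher numbers for weaker inhibition), two compounds that share one core have been measured so far. Compound 1 `O=C(CCc1cccc2c1B(O)OC2)Nc1cccc(Br)c1`, which carries a bromo group, gives 20000 nM. Compound 2 `N#Cc1cccc(-c2cccc(NC(=O)CCc3cccc4c3B(O)OC4)c2)c1`, with a 3-cyanophenyl group in that place, gives 7300 nM, the lower of the two numbers. Compound 3 `N#Cc1ccc(-c2cccc(NC(=O)CCc3cccc4c3B(O)OC4)c2)cc1` differs from compound 2 in one place, with 4-cyanophenyl in place of 3-cyanophenyl on an aromatic carbon. The two have the same atoms, joined differently. For the measured compounds named here, only one measured step bears on this change, and only loosely: a 2.7-fold lower number from compound 1 to compound 2 (0.44 log units; beyond the scatter). That modest step exchanged a bromo group for a whole cyanophenyl group, whereas the new change keeps the cyanophenyl group and only shifts where its nitrile is attached. Going by the values given here, no measured pair shows such a shift directly, so the data favour no direction, and no change beyond the scatter is expected in this assay. The expected step is a 1.1-fold higher number from compound 2 to compound 3 (0.04 log units; within the scatter). For compound 3 the estimated value is 8000 nM, with an expected range from 3500 nM to 17000 nM.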

Compound 3, half-maximal inhibitory concentration: 12000 nM
The estimate for compound 3 lay 1.5-fold (0.18 log units) below the measured number; the range from low to high includes it.
By their numbers in this assay, from the lowest: compounds 2, 3 and 1 (each within the scatter of the next, the first and the last beyond it).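

In this assay the change shows that moving the nitrile within the cyanophenyl group, on this aromatic carbon meta to a large group, gives a 1.6-fold higher number from compound 2 to compound 3 (0.22 log units; within the scatter) and so produces no readable difference between the two isomers. The second new step, a 1.7-fold lower number from compound 1 to compound 3 (0.22 log units; within the scatter), adds what the earlier pair could not show: exchanging bromo for 4-cyanophenyl does not clear the scatter, whereas the earlier exchange for 3-cyanophenyl, a 2.7-fold lower number from compound 1 to compound 2 (0.44 log units; beyond the scatter), did, so the step beyond the scatter belongs to compound 2 alone and not to both cyanophenyl isomers, with compound 3 lying within the scatter of both compound 1 and compound 2. Nothing available here accounts for this outcome.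

The three compounds leave open whether a 2-cyanophenyl group, a plain phenyl group, or a phenyl group carrying an amine or a carboxylic acid in place of the nitrile would give a number separated from these by more than the scatter. They also leave open whether a longer chain on the amide side of the shared core would alter the picture, since every compound shown keeps that part unchanged.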